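The source may report more compounds than this note shows. Statements on the series, on what has been measured and on what is new or still open speak of the compounds shown alone.

Working notes on the series.

Compound 1 `Cc1ccc(-c2nc(N)c3ccsc3n2)o1` carries a 5-methylfuran-2-yl group on the shared core and no benzyl. In a functional assay on CHO-K1 cells for antagonist activity at adenosine receptor A1 (Homo sapiens), read by a beta-galactosidase reporter and cAMP accumulation, with stated times of 15 min and 6 h (on this read-out lower numbers stand for stronger inhibition and higher numbers for weaker inhibition), compound 1 gives 493 nM. Compound 2 `Cc1ccc(-c2nc(N)c3cc(Cc4ccccc4)sc3n2)o1` adds a benzyl on an aromatic carbon of the core; in this assay compound 2 gives 298 nM, the step being a 1.7-fold lower number from compound 1 to compound 2 (0.22 log units; within the scatter). Compound 3 `COc1ccccc1Cc1cc2c(N)nc(-c3ccc(C)o3)nc2s1` adds a methoxy to that benzyl; in this assay compound 3 gives 122 nM, with the step of a 2.4-fold lower number from compound 2 to compound 3 (0.39 log units; beyond the scatter).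

Among the three numbers compound 2 stands second highest: nearest is compound 1, and the furthest is compound 3, whose step from compound 2 is the only one beyond the scatter.

Compound 4 `Nc1nc(-c2ncccn2)nc2sc(Cc3ccccc3)cc12` differs from compound 2 in one place: pyrimidin-2-yl in place of 5-methylfuran-2-yl on an aromatic carbon. The 5-methylfuran-2-yl leaves and the pyrimidin-2-yl enters at the aromatic carbon between two ring nitrogen atoms, while the benzyl of compound 2 remains.

Neither measured step bears on this place. Both steps, from compound 1 to compound 2 and from compound 2 to compound 3, change the benzyl or its methoxy and leave the group between the ring nitrogen atoms untouched. The series gives no guide to the size or direction of the change, so no step beyond the scatter is expected, with a wide range. In this assay compound 4 is estimated at 400 nM, between 80 nM and 2000 nM, meaning an expected step of a 1.3-fold higher number from compound 2 to compound 4 (0.13 log units; within the scatter).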

Compound 4, inhibition constant: 618 nM
For compound 4 the middle estimate is 1.5-fold (0.19 log units) below the measured one, and the stated range covers the measured number.
By their numbers in this assay, from the lowest: compound 3; then compounds 2, 1 and 4 (each within the scatter of the next, the first and the last beyond it).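

In this assay, among the compounds shown here, the earlier steps touched only the benzyl and its methoxy; this one shows that the group on the aromatic carbon between two ring nitrogen atoms also moves the number, with pyrimidin-2-yl in place of 5-methylfuran-2-yl giving a 2.1-fold higher number from compound 2 to compound 4 (0.32 log units; beyond the scatter) while the benzyl stays. The step is modest and points towards weaker inhibition, so this exchange of a five-membered aromatic ring with 1 hetero atom for a six-membered aromatic ring with 2 hetero atoms, at an equal count of heavy atoms, lowers the strength of inhibition without abolishing it. Nothing at hand accounts for this step.

From the compounds shown here alone, whether the step keeps its size and direction with the methoxy of compound 3 on the benzyl remains open. Also open, going by these compounds, is how a phenyl, a plain furan-2-yl without the methyl, or a small alkyl chain on this aromatic carbon would read, and so which part of the exchange carries the change: the ring size, the ring nitrogen atoms or the loss of the methyl.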